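Chain-End Swap on a Shared Sulfonamide Core

This account rests on a few compounds, and the source may have more. Where it says the series, first, only, none or still open, it means among the compounds named here.

Compound 1 `COc1cccc(Sc2c(NS(=O)(=O)c3ccc(C(C)(C)C)cc3)noc2CCCC#N)c1`: 520 nM
Compound 2 `COc1cccc(Sc2c(NS(=O)(=O)c3ccc(C(C)(C)C)cc3)noc2C)c1`: 300 nM
Compound 3 `COc1cccc(Sc2c(NS(=O)(=O)c3ccc(C(C)(C)C)cc3)noc2CCO)c1`: 430 nM

In an assay on COS-7 cells for displacement of a labelled ligand from Endothelin receptor type B (Sus scrofa) (on this read-out higher numbers stand for weaker inhibition and lower numbers for stronger inhibition), compound 3 stands second highest of the three numbers, with compound 1 nearest and compound 2 furthest, and all three lie within the scatter of one another. Compound 4 `COc1cccc(Sc2c(NS(=O)(=O)c3ccc(C(C)(C)C)cc3)noc2CCCC(N)=O)c1` is the untested partner; the change is carbamoylmethyl in place of hydroxy on a saturated chain carbon, two bonds along the chain from an aromatic carbon. Among the compounds with values here, two measured steps touch this chain. The step of a 1.2-fold lower number from compound 1 to compound 3 (0.08 log units; within the scatter) swapped one chain end for another at the same place, and a 1.4-fold higher number from compound 2 to compound 3 (0.16 log units; within the scatter) added the whole chain; a 1.7-fold lower number from compound 1 to compound 2 (0.24 log units; within the scatter) removed a longer chain. None of these steps left the scatter, so no step beyond the scatter is expected here either. Compound 4 is therefore expected to give 450 nM, within 200 nM to 1000 nM, an estimated step of a 1.0-fold higher number from compound 3 to compound 4 (0.02 log units; within the scatter).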

Compound 4, half-maximal inhibitory concentration: 240 nM
Beside the measured number, compound 4's estimate is 1.9-fold (0.27 log units) above it; the range from low to high includes it.
By their numbers in this assay, from the lowest: compounds 4, 2, 3 and 1 (each within the scatter of the next, the first and the last beyond it).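

Carbamoyl in place of cyano at the chain end gives a 2.2-fold lower number from compound 1 to compound 4 (0.34 log units; beyond the scatter) in this assay and is the first step in this set to leave the scatter, so the chain end can matter here, though only modestly. The other two new steps, a 1.8-fold lower number from compound 3 to compound 4 (0.25 log units; within the scatter) and a 1.3-fold lower number from compound 2 to compound 4 (0.10 log units; within the scatter), stay within the scatter, so 3-carbamoylpropyl cannot be told apart from 2-hydroxyethyl or from the small group of compound 2. No measurement here offers a cause for the carbamoyl and cyano difference.

On these data alone, whether a carboxylic acid or an amine at this chain end would move the number further stays open, and so does the effect of a longer chain carrying the carbamoyl group.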